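A few compounds are considered here, and "the series" means these few. Any claim that something is new, unique, unknown or untested is made for them only; others in the source may bear on it.

Measured compounds in a functional assay on A375P cells (Homo sapiens) for antiproliferative activity, read by MTT assay, with a stated time of 48 h; a lower number here means a stronger inhibitor, a higher number a weaker inhibitor:
compound 1 `Cc1ccc(C(=O)Nc2cccc(-c3ccnc4c(N)cccc34)c2)cc1C` gives > 20000 nM, a limit of the assay
compound 2 `Nc1cccc2c(-c3cccc(NC(=O)c4ccc(F)c(C(F)(F)F)c4)c3)ccnc12` gives 10400 nM
compound 3 `Nc1cccc2c(-c3cccc(NC(=O)c4cc(Cl)cc(C(F)(F)F)c4)c3)ccnc12` gives 18500 nM

All three share the same core and differ only in the aryl group on the carbonyl carbon of the amide. For compound 1 this assay reports no number, only a limit; it stands at the limit of > 20000 nM in this assay, at which 1 of the 3 values shown sits. Compound 2 and compound 3 return numbers that lie within the usual scatter of each other, so nothing separates them, and both sit in the weak range of this assay.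

Compound 4 `Nc1cccc2c(-c3cccc(NC(=O)c4cc5ccccc5s4)c3)ccnc12` has not yet been measured. It differs from compound 1 by 1-benzothiophen-2-yl in place of 3,4-dimethylphenyl on a carbonyl carbon. Among the measured compounds shown here, no step between two measured compounds is available to calibrate this change, so the expectation rests on the spread of the measured set. Compound 2 gives 10400 nM and compound 3 gives 18500 nM with other aryl groups on the carbonyl carbon, and compound 4 is expected to fall in that same weak region, around 11000 nM, within 3500 nM to 30000 nM. Measured against compound 1, this would mean an expected step of an at least 1.8-fold lower number from compound 1 to compound 4 (0.25 log units; that floor lies within the scatter), at most modest, with a real chance that this assay again returns only a limit.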

Compound 4, half-maximal inhibitory concentration: > 20000 nM
Compound 4 gave a limit, no number; the forecaster's own chance of this, stated with the estimate: 35%; middle value at least 1.8-fold (0.25 log units) away from the limit.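

Compound 4, like compound 1, returns only a limit and no number in this assay, and the step between the two cannot be read: the limit of > 20000 nM in this assay, at which 2 of the 4 values shown sit. The compounds shown leave open how the 1-benzothiophen-2-yl and 3,4-dimethylphenyl groups compare on the carbonyl carbon, and how far compound 1 and compound 4 lie from compound 2 and compound 3.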